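The source may report more compounds than this note shows. Statements on the series, on what has been measured and on what is new or still open speak of the compounds shown alone.

In a functional assay on a cell-free system (plasma) for inhibition of platelet-activating factor acetylhydrolase (Homo sapiens), tested at 100 nM (a higher number here means more inhibition at the concentration tested (going by the name of the read-out), a lower number less inhibition), the three measured compounds gave the following numbers:

Compound 1, `CCCCCCCCN(C)C(=O)Cn1cc(Cc2cnc(=O)n(CCO)c2)c(=O)nc1SCc1ccc(F)cc1`, gives 59%.
Compound 2, `CCCCCCCCN(C)C(=O)Cn1cc(Cc2cnc(=O)n(CC(=O)NC)c2)c(=O)nc1SCc1ccc(F)cc1`, gives 63%.
Compound 3, `CCCCCCCCN(C)C(=O)Cn1cc(Cc2cnc(=O)n(CC(=O)N3CCOCC3)c2)c(=O)nc1SCc1ccc(F)cc1`, gives 64%.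

Compound 3 is not separated from its two neighbours on these numbers: the steps to it are a number 5 percentage points higher from compound 1 to compound 3 (within the scatter) and a number 1 percentage points higher from compound 2 to compound 3 (within the scatter), and the remaining pair shows a number 4 percentage points higher from compound 1 to compound 2 (within the scatter). All three compounds share one core and differ only in the group on the saturated chain carbon bound to the aromatic nitrogen, and none of those changes moved the read-out beyond the scatter.

Compound 4, `CCCCCCCCN(C)C(=O)Cn1cc(Cc2cnc(=O)n(CC(=O)N3CCN(C)CC3)c2)c(=O)nc1SCc1ccc(F)cc1`, carries the next change in the same part of the molecule: 4-methylpiperazin-1-yl in place of morpholin-4-yl on a carbonyl carbon. Among the measured compounds shown here, the step that bears most directly on it is the one from compound 2 to compound 3, which also swapped the group on that carbonyl carbon and gave a number 1 percentage points higher from compound 2 to compound 3 (within the scatter). The two steps from compound 1 touched the same position and were likewise small. On this evidence no step beyond the scatter is expected in this assay, in either direction.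

Compound 4 is therefore estimated at 64%, with a range from 52% to 76%. The step of no change at the digits printed from compound 3 to compound 4 (within the scatter) is expected to stay within the scatter.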

Compound 4, a percentage reported as inhibition, at one concentration (the size of the read-out at that concentration, not a potency): 68%
The estimate for compound 4 lay 4 percentage points below the measured number; the range from low to high includes it.
By their numbers in this assay, from the lowest: compounds 1, 2, 3 and 4 (each within the scatter of the next).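

In this assay, the carbonyl carbon whose other neighbour is the saturated chain carbon now also carries 4-methylpiperazin-1-yl, which has a second ring nitrogen where morpholin-4-yl has oxygen, and the read-out does not separate the two groups: the result is a number 4 percentage points higher from compound 3 to compound 4 (within the scatter), and against the methylamino group it is a number 5 percentage points higher from compound 2 to compound 4 (within the scatter). The change from hydroxymethyl to (4-methylpiperazin-1-yl)carbonyl on the saturated chain carbon bound to the aromatic nitrogen gives the largest step in the set, a number 9 percentage points higher from compound 1 to compound 4 (within the scatter), so even this widest pair does not leave the scatter, and the four groups shown cannot be ranked at this position. Nothing available explains how these groups compare in this assay.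

The compounds shown leave open whether a carboxylic acid, a primary amine or a longer chain on that same saturated chain carbon would move the read-out beyond the scatter. Because all four were read at a single concentration, they also leave open whether full concentration-response measurements would separate them.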